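Acid Dissociation From Compound 2 to Compound 4

The source may hold more compounds than are shown below. What is called first, only, known or untested is meant among the compounds shown, and "the series" means these compounds.

In a physicochemical assay for acid dissociation, three compounds have been measured:
Compound 1 `COc1ccc(N(Cc2nnn[nH]2)Cc2ccc(Cl)cc2Cl)cc1` gives 4.29
Compound 2 `Fc1cccc(CN(Cc2nnn[nH]2)c2ccccc2)c1` gives 4.19
Compound 3 `Fc1ccc(CN(Cc2nnn[nH]2)c2ccccc2)c(F)c1` gives 4.13

Compound 2 sits between the other two on these numbers, yet its value lies within the scatter of compound 3 and within the scatter of compound 1, so the three are not told apart. The untested compound 4 `Clc1ccc(CN(Cc2nnn[nH]2)c2ccccc2)cc1` differs from compound 2 in one place: 4-chlorophenyl in place of 3-fluorophenyl on a saturated chain carbon bound to a nitrogen on an aromatic ring. Among the compounds with values here, no step between measured compounds is available for this change, but since compounds 1, 2 and 3 carry varied halogenated rings at the same place and agree within the scatter, no step beyond the scatter is expected in this assay. Compound 4 is therefore estimated at 4.2, ranging from 3.9 to 4.5, an expected step of a number 0.01 log units higher from compound 2 to compound 4 (within the scatter).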

Compound 4, acid dissociation constant: 4.38
Compound 4: the middle estimate sits 0.18 log units below what was measured; the measured number falls inside the stated range.
By their numbers in this assay, from the lowest: compounds 3, 2, 1 and 4 (each within the scatter of the next).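

In this assay, 4-chlorophenyl in place of 3-fluorophenyl on a saturated chain carbon bound to a nitrogen on an aromatic ring now has a directly measured step (a number 0.19 log units higher from compound 2 to compound 4 (within the scatter)). Within the data shown here, this single-place comparison, which the earlier compounds did not offer, does not tell the two groups apart. Nothing measured bears on the reason for the size of this step.

Still open, on these data alone, is whether an amine or a carboxylic acid on this phenyl ring would give a step beyond the scatter. A longer chain at this place leaves the same question open.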